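A few compounds are considered here, and "the series" means these few. Any claim that something is new, unique, unknown or untested is made for them only; others in the source may bear on it.

Compound 1 `Cc1cc(C)c(CN2CCc3c(Cl)cc([C@@H](C)CO)c(Cl)c3C2=O)c(=O)[nH]1` is measured in an ADME assay on MDCK cells (Canis lupus familiaris) for permeability, read by LC-MS, with a stated time of 90 min, tested at 2 uM (a higher number here means that the compound crosses the layer faster, a lower number that the compound crosses the layer more slowly), where compound 1 gives 15 10^-6 cm/s. That is the only single number shown for a compound in this assay; compound 2 `COC(c1cc(Cl)c2c(c1Cl)C(=O)N(Cc1c(C)cc(C)[nH]c1=O)CC2)C1CCOC1` also has entries, but several of them rather than one, namely 17.1 10^-6 cm/s; 18.7 10^-6 cm/s; 15.4 10^-6 cm/s; 18.4 10^-6 cm/s (4 entries). For the measured compounds named here, the repeated readings of compound 2 the several entries of compound 2 in this assay, 17.1 10^-6 cm/s; 18.7 10^-6 cm/s; 15.4 10^-6 cm/s; 18.4 10^-6 cm/s (4 entries) sit close together, and they lie in the same region as the single reading of compound 1.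

Compound 3 `Cc1cc(C)c(CN2CCc3c(Cl)cc([C@H](CO)[C@H]4CCCO4)c(Cl)c3C2=O)c(=O)[nH]1` is the next compound to be measured in this assay. It differs from compound 1 in one place (oxolan-2-yl in place of methyl on a saturated chain carbon bound to an aromatic carbon and a saturated chain carbon). Going by the values given here, no measured pair in this set differs in exactly this way, so there is no measured step to lean on. What the two measured compounds show is that a compound carrying an oxolan-2-yl group, compound 2, and a compound carrying a methyl group at that place, compound 1, give readings within the scatter of one another. On that basis the step of a 1.1-fold lower number from compound 1 to compound 3 (0.03 log units; within the scatter) is expected to be small, in no clear direction, and compound 3 is estimated to give 14 10^-6 cm/s, most likely between 7 10^-6 cm/s and 26 10^-6 cm/s.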

Compound 3, apparent permeability: 4.1 10^-6 cm/s
Beside the measured number, compound 3's estimate is 3.4-fold (0.53 log units) above it; measured number outside the range, below it.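

At the saturated chain carbon bound to an aromatic carbon and a saturated chain carbon, the swap in this assay is not neutral: oxolan-2-yl in place of methyl gives a 3.7-fold lower number from compound 1 to compound 3 (0.56 log units; beyond the scatter). For the compounds shown here, this is the first measured step in the set between two compounds that differ in one place, and it shows that a change at this position can move the number beyond the usual scatter. Even so, a low number does not always come with an oxolane ring, since compound 2 carries one as well, although it differs from compound 3 in more than one place and gives no clean step: the several entries of compound 2 in this assay, 17.1 10^-6 cm/s; 18.7 10^-6 cm/s; 15.4 10^-6 cm/s; 18.4 10^-6 cm/s (4 entries)

Which part of the change goes with the lower number stays open, whether that is the ring, its oxygen, the larger size of the group, or the defined stereocentre that enters with it. Going by these compounds, how a cyclopentyl ring, which keeps the ring but has no oxygen, or a longer open carbon chain would read at this same place also remains unknown.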